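The source may hold more compounds than are shown below. What is called first, only, known or untested is meant among the compounds shown, and "the series" means these compounds.

Working notes on the series around the shared core of compound 1.

Compound 1 `CC(=O)OCc1ccc2oc(=O)c(C(=O)Sc3ccccc3)cc2c1` gives, in a functional assay on HT-1080 cells (Homo sapiens), read by transwell migration, with a stated time of 24 h, tested at 10 uM (a higher number here means a weaker effect of the compound at the concentration tested, a lower number a stronger effect), 73.8%. Compound 2 `CC(=O)OCc1ccc2oc(=O)c(C(=O)Sc3cccc(Br)c3)cc2c1` gives 67.8% in this assay. Within the data shown here, the step of a number 6 percentage points lower from compound 1 to compound 2 (within the scatter) is the only measured one-place change and stays within the scatter.

Compound 3 `CCCC(=O)OCc1ccc2oc(=O)c(C(=O)Oc3cccc(Br)c3)cc2c1` gives 24.7% and stands lowest of the three numbers: compound 2 sits higher by a gap beyond the scatter, and compound 1 higher still, also beyond the scatter. Among the measured compounds shown here, no single-place step links compound 3 to either of them, so those gaps are only what the two values show.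

Compound 4 `CC(C)C(=O)OCc1ccc2oc(=O)c(C(=O)Oc3cccc(Br)c3)cc2c1` is the next compound to be measured. Its difference from compound 3 is isopropyl in place of propyl on a carbonyl carbon. For the measured compounds named here, no measured step touches this part of the molecule: the one step known, on an aromatic carbon, is unrelated to the chain on the carbonyl carbon and gives no guidance on direction. With nothing bearing on the change, no step beyond the scatter is expected, and the estimated step of a number 2.3 percentage points higher from compound 3 to compound 4 (within the scatter) is taken as near zero. Compound 4 is therefore expected to give about 27%, in the range 12% to 45%.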

Compound 4, a percentage reported as activity, at one concentration (the size of the read-out at that concentration, not a potency): 21.1%
Compound 4: middle estimate off by 5.9 percentage points, on the high side, within the range that was stated.
By their numbers in this assay, from the lowest: compounds 4 and 3 (each within the scatter of the next); then compounds 2 and 1 (each within the scatter of the next).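

Among these compounds, the step of a number 3.6 percentage points lower from compound 3 to compound 4 (within the scatter) is the first measured change at this position, on a carbonyl carbon whose other neighbours are: oxygen next to a carbonyl group, and it adds a reading that the aromatic bromo step could not give. Propyl and isopropyl have the same count of 3 carbon atoms, joined differently, so for this pair in this assay rearranging the chain at this place gives no difference that can be told from the scatter, and the two compounds can be treated as equivalent in this one read-out. No measured evidence accounts for this outcome, so the result stands as an observation only.

The compounds shown leave open how far this tolerance extends, since only two chains of one size are compared here and a longer chain, a phenyl ring, an amine or a carboxylic acid at the same carbonyl carbon could read differently. Among the compounds shown here, they also leave open what separates compounds 3 and 4 from compounds 1 and 2, as no single-place step joins the two pairs.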